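Swapping a urea for a sulfonamide on a sugar-linked enone

This account rests on a few compounds, and the source may have more. Where it says the series, first, only, none or still open, it means among the compounds named here.

Compound 1 `CC(=O)OC[C@H]1O[C@@H](CC(=O)/C=C/c2cccc(NC(=O)Nc3ccccc3)c2)[C@@H](OC(C)=O)[C@@H](OC(C)=O)[C@@H]1OC(C)=O` and compound 2 `CC(=O)OC[C@H]1O[C@@H](CC(=O)/C=C/c2cccc(NS(=O)(=O)c3ccc(C)cc3)c2)[C@@H](OC(C)=O)[C@@H](OC(C)=O)[C@@H]1OC(C)=O` share a fully acetylated sugar core. In an ADME assay on Vero cells (Chlorocebus sabaeus) for cytotoxicity, read by resazurin assay, with a stated time of 2 days (a higher number here means that more compound is tolerated, a lower number that less compound is tolerated), compound 1 gives 102000 nM, and compound 2 gives 123000 nM. The change between them, ((4-methylphenyl)sulfonyl in place of phenylcarbamoyl on a nitrogen on an aromatic ring), produced a 1.2-fold higher number from compound 1 to compound 2 (0.08 log units; within the scatter). Compound 3 `O=C(/C=C/c1cccc(NC(=O)Nc2ccccc2)c1)C[C@@H]1O[C@H](CO)[C@@H](O)[C@H](O)[C@@H]1O` carries the same urea on a core whose sugar hydroxyls are free; the difference between its core and that of compound 1 is not broken down here, and in this assay compound 3 gives "not determined" (no result reported), so no number is available for it. Compound 4 `Cc1ccc(S(=O)(=O)Nc2cccc(/C=C/C(=O)C[C@@H]3O[C@H](CO)[C@@H](O)[C@H](O)[C@@H]3O)c2)cc1` arises from compound 3 by the same change, ((4-methylphenyl)sulfonyl in place of phenylcarbamoyl on a nitrogen on an aromatic ring), at the same place. Since that change moved compound 1 to compound 2 by only a 1.2-fold higher number from compound 1 to compound 2 (0.08 log units; within the scatter), a small step is expected from compound 3 to compound 4 as well. In this assay compound 4 is estimated at 120000 nM, with a likely range from 40000 nM to 400000 nM.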

Compound 4, half-maximal cytotoxic concentration: 417000 nM
Estimate against measurement, compound 4: 3.5-fold (0.54 log units) below; the whole stated range lies below it.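

With no number for compound 3 in this assay, the step from compound 3 to compound 4 cannot be read. On these data alone, whether this swap changes as little on the free-hydroxyl core as on the acetylated core stays open. Nothing shown accounts for the result for compound 4.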